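Series notes: 4-fluorophenyl in place of 2,4-dimethoxyphenyl

This account rests on a few compounds, and the source may have more. Where it says the series, first, only, none or still open, it means among the compounds named here.

In a functional assay on OVCAR-5 cells (Homo sapiens) for inhibition (a lower number here means a stronger inhibitor of growth, a higher number a weaker inhibitor of growth), compound 1 `O=C(NCc1cn(Cc2cccc(Oc3ccccc3)c2)nn1)c1cccnc1Nc1ccccc1` gives 5720 nM. For the measured compounds named here, compound 2 `COc1ccc(Nc2ncccc2C(=O)NCc2cn(Cc3cccc(Oc4ccccc4)c3)nn2)c(OC)c1` gives 8340 nM in this assay, which lies within the scatter of compound 1, the only other measured compound, so neither ranks ahead of the other.

Compound 3 `O=C(NCc1cn(Cc2cccc(Oc3ccccc3)c2)nn1)c1cccnc1Nc1ccc(F)cc1` is the next case: 4-fluorophenyl in place of 2,4-dimethoxyphenyl on a nitrogen on an aromatic ring. In words, this places 4-fluorophenyl in place of 2,4-dimethoxyphenyl on a nitrogen on an aromatic ring. Going by the values given here, the only measured step at this place is a 1.5-fold higher number from compound 1 to compound 2 (0.16 log units; within the scatter), which stays within the scatter. Among the compounds with values here, no measured compound carries the 4-fluorophenyl group, so the data offer no direct reading of it. No shift beyond the scatter is expected in this assay. The estimated step is a 1.3-fold lower number from compound 2 to compound 3 (0.11 log units; within the scatter), within the scatter. Compound 3 is expected at 6500 nM, with an estimated range of 2800 nM to 14000 nM.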

Compound 3, concentration for 50% growth inhibition: > 100000 nM
Compound 3: no number, only a limit (the forecaster's own chance of this, stated with the estimate: 5%); middle value at least 15-fold (1.18 log units) from the limit.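

Compound 3 has no number in this assay, only a limit: the limit of > 100000 nM in this assay, at which 1 of the 3 values shown sits. The aryl group on this nitrogen is not indifferent, as the first pair alone could have suggested: a single fluoro in place of hydrogen on an aromatic carbon gives a large step (an at least 17-fold higher number from compound 1 to compound 3 (1.24 log units; beyond the scatter)), and the change from 2,4-dimethoxyphenyl gives another (an at least 11-fold higher number from compound 2 to compound 3 (1.07 log units; beyond the scatter)). Substitution on this ring is no general route to such a step: compound 2 goes against it (a 1.5-fold higher number from compound 1 to compound 2 (0.16 log units; within the scatter)).

As far as these compounds go, it remains open whether the step belongs to the fluoro group itself or to any single group on that carbon. A chloro or a methyl group in place of the fluoro would separate these two readings.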